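The compounds below may be only part of what the source reports. "The series", "measured", "known", "first", "only" and "open" are said of these compounds alone.

Working notes on the series. Compound 1 `Cn1nc(Cc2nnc(SCCCCCCCC(=O)Nc3ccc(Cl)cc3Cl)n2CCCO[Si](C)(C)C(C)(C)C)c2ccccc2c1=O` carries the protected chain. In an assay on 32D cells for inhibition of interleukin-15 (Mus musculus), read by resazurin assay, with stated times of 30 min and 2.5 days, in the presence of a further agent that is not named here (on this read-out higher numbers stand for weaker inhibition and lower numbers for stronger inhibition), compound 1 gives only a limit, > 30000 nM. Compound 2 `Cn1nc(Cc2nnc(SCCCCCCCC(=O)Nc3ccc(Cl)cc3Cl)n2CCCO)c2ccccc2c1=O` has the free chain. In this assay compound 2 likewise gives a limit, > 30000 nM. The step that the two limits leave unreadable from compound 1 to compound 2 is therefore unreadable. Compound 3 `Cn1c(Cc2nn(CCCO)c(=O)c3ccccc23)nnc1SCCCCCCCC(=O)Nc1ccc(Cl)cc1Cl` is the isomer with the chain on the aromatic nitrogen. In this assay compound 3 also returns a limit, > 30000 nM. For the measured compounds named here, all values so far sit at the limit of > 30000 nM in this assay, at which 3 of the 3 values shown sit, so compound 3 cannot be placed against the other two. Compound 4 `Cn1c(Cc2n[nH]c(=O)c3ccccc23)nnc1SCCCCCCCC(=O)Nc1ccc(Cl)cc1Cl` differs from compound 3 by hydrogen in place of 3-hydroxypropyl on an aromatic nitrogen. Going by the values given here, no measured step reads on this change, and nothing measured yet falls below the limit. Compound 4 is therefore expected to stay near the limit, estimated at 40000 nM (range 10000 nM to 150000 nM). The expected step that the limit leaves unreadable from compound 3 to compound 4 is likely not readable.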

Compound 4, half-maximal inhibitory concentration: > 30000 nM
Compound 4: no number, only a limit; the forecaster's own chance of this, stated with the estimate: 80%; the middle value is on the limit's open side.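

No step can be read from compound 3 to compound 4, since both give only limits in this assay: the limit of > 30000 nM in this assay, at which 4 of the 4 values shown sit. The compounds shown leave open which structural change, if any, would bring a measurable value in this assay.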